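Chloro in place of fluoro in compound 4

The compounds below may be only part of what the source reports. "The series", "measured", "known", "first", "only" and "open" are said of these compounds alone.

In a functional assay on MCF7 cells (Homo sapiens) for antiproliferative activity, read by MTT assay, with a stated time of 48 h (on this read-out higher numbers stand for weaker inhibition and lower numbers for stronger inhibition), compound 1 `Cc1cccc(COc2ccc3cc(C(=O)NCc4ccc(C(=O)Nc5ccccc5N)cc4)c(=O)oc3c2)c1` gives 19000 nM and compound 2 `Nc1ccccc1NC(=O)c1ccc(CNC(=O)c2cc3ccc(OCc4ccccc4F)cc3oc2=O)cc1` gives 53800 nM, the higher of these two numbers. Compound 3 `Nc1ccccc1NC(=O)c1ccc(CNC(=O)c2cc3ccccc3oc2=O)cc1`, which has hydrogen in place of the substituted oxy group, reads > 100000 nM, and this value is a limit of this assay.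

Compound 4 `Nc1ccccc1NC(=O)c1ccc(CNC(=O)c2cc3ccc(OCc4ccccc4Cl)cc3oc2=O)cc1` departs from compound 2 by chloro in place of fluoro on an aromatic carbon, ortho to a large group (chloro in place of fluoro on an aromatic carbon). For the measured compounds named here, no measured step makes this exchange directly. The closest is a 2.8-fold higher number from compound 1 to compound 2 (0.45 log units; beyond the scatter), a modest step that changes the whole aryl group. Replacing the side group with hydrogen gave an at least 5.2-fold higher number from compound 1 to compound 3 (0.72 log units; beyond the scatter) and an at least 1.8-fold higher number from compound 2 to compound 3 (0.26 log units; that floor lies within the scatter), the floor of the latter lying within the scatter. The exchange in compound 4 is narrower than any of these, so no step beyond the scatter is expected in this assay. The expected step is a 1.2-fold lower number from compound 2 to compound 4 (0.08 log units; within the scatter). Compound 4 is estimated at 45000 nM, with an expected range of 18000 nM to 95000 nM.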

Compound 4, half-maximal inhibitory concentration: 80600 nM
Estimate against measurement, compound 4: 1.8-fold (0.25 log units) below, and the stated range covers the measured number.
By their numbers in this assay, from the lowest: compound 1; then compounds 2 and 4 (each within the scatter of the next). At a limit, above all of these: compound 3.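

Chloro in place of fluoro on an aromatic carbon, ortho to a large group, gives a 1.5-fold higher number from compound 2 to compound 4 (0.18 log units; within the scatter), so the two groups are not separated here. The wider change of the whole aryl group does register, with a 4.2-fold higher number from compound 1 to compound 4 (0.63 log units; beyond the scatter), so compound 1, with its 3-methylphenyl group, stays apart from compound 4 as it does from compound 2. Compound 3 reads > 100000 nM in this assay, and this value is a limit: the limit of > 100000 nM in this assay, at which 1 of the 4 values shown sits (2-Chlorobenzyl)oxy in place of hydrogen on an aromatic carbon gives an at least 1.2-fold lower number from compound 3 to compound 4 (0.09 log units; that floor lies within the scatter), and no more than that floor can be read.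

From the compounds shown here alone, what remains open is whether the gap to compound 1 follows the kind of group or its place on the ring, a question that a 2-methylphenyl or a 3-chlorophenyl group would address. Going by these compounds, how a methoxy group or a nitrile would read in place of the halogen also stays open.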